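Swapping 2,4-difluorophenyl for 2-nitrophenyl in an antiproliferative series

A few compounds are considered here, and "the series" means these few. Any claim that something is new, unique, unknown or untested is made for them only; others in the source may bear on it.

Two related compounds have been taken into a functional assay on HeLa cells (Homo sapiens) for antiproliferative activity, read by MTT assay, with a stated time of 72 h; a lower number here means a stronger inhibitor, a higher number a weaker inhibitor. For compound 1 `Cc1ccccc1N1CCN(C(=S)SCc2ccc3nc(N)nc(N)c3c2)CC1` the entry reads "not determined" (no result reported), so it offers no number for comparison. Among the compounds with values here, compound 2 `Nc1nc(N)c2cc(CSC(=S)N3CCN(c4ccc(F)cc4F)CC3)ccc2n1` gives 3800 nM, the only number available, which means it cannot yet be ranked against anything. Compound 3 `Nc1nc(N)c2cc(CSC(=S)N3CCN(c4ccccc4[N+](=O)[O-])CC3)ccc2n1` keeps the rest of compound 2 and changes one group, on an amine nitrogen in a ring: 2-nitrophenyl in place of 2,4-difluorophenyl on an amine nitrogen in a ring. Within the data shown here, no measured pair shows what a change at this place does, so the expectation rests on the structural change alone. In this assay, no step beyond the usual scatter is expected, and no direction can be firmly argued. The expected step is a 1.3-fold lower number from compound 2 to compound 3 (0.10 log units; within the scatter), an estimate that carries wide uncertainty. For compound 3 the estimated value is 3000 nM, with an expected range of 900 nM to 10000 nM.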

Compound 3, half-maximal inhibitory concentration: 4880 nM
Estimate against measurement, compound 3: 1.6-fold (0.21 log units) below, and the stated range covers the measured number.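

In this assay, the only step shown at this place is a 1.3-fold higher number from compound 2 to compound 3 (0.11 log units; within the scatter), so on this amine nitrogen in a ring the two groups cannot be told apart. This holds although the exchange is not a close one: 2,4-difluorophenyl has 0 hydrogen-bond acceptors and 2-nitrophenyl has 2, while both keep one six-membered aromatic ring of carbon only. Nothing measured bears on why the step has this size.

Within the data shown here, compound 1 has no number, so no step to it can be read, and this single step rests on compounds 2 and 3 alone. As far as these compounds go, whether a phenyl group carrying an amine or a carboxylic acid, or a benzyl group, on this nitrogen would give a step beyond the scatter remains open.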